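A few compounds are considered here, and "the series" means these few. Any claim that something is new, unique, unknown or untested is made for them only; others in the source may bear on it.

Among the compounds with values here, in a functional assay on KB cells (Homo sapiens) for inhibition (on this read-out higher numbers stand for weaker inhibition and lower numbers for stronger inhibition), compound 1 `N#C/N=C(\N)c1cn([C@@H]2O[C@H](CO)[C@@H](O)[C@H]2O)c2nnnc(N)c12` gives 5000 nM, the only actual number so far. Compound 2 `NC(=O)c1cn([C@@H]2O[C@H](COC(=O)c3ccccc3)[C@@H](OC(=O)c3ccccc3)[C@H]2OC(=O)c2ccccc2)c2nnnc(O)c12` reads > 10000 nM, which is a limit and not a number. Compound 3 `COC(=N)c1cn([C@@H]2O[C@H](CO)[C@@H](O)[C@H]2O)c2nnnc(N)c12` keeps the core of compound 1 and changes only the group on an aromatic carbon of the five-membered aromatic ring: a group of 4 heavy atoms (2 carbon, 1 nitrogen, 1 oxygen; no ring) in place of a group of 5 heavy atoms (2 carbon, 3 nitrogen; no ring), on an aromatic carbon. Within the data shown here, no measured step covers this change, so the expectation is loose. The expected 3.3-fold lower number from compound 1 to compound 3 (0.52 log units; beyond the scatter) in this assay is a modest move toward stronger inhibition. For compound 3 the estimated value is 1500 nM, with an expected range of 150 nM to 10000 nM.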

Compound 3, half-maximal inhibitory concentration: 20000 nM
Beside the measured number, compound 3's estimate is 13-fold (1.12 log units) below it, outside the stated range (above it).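

Replacing the group of 5 heavy atoms with the group of 4 heavy atoms on this aromatic carbon gives, in this assay, a 4.0-fold higher number from compound 1 to compound 3 (0.60 log units; beyond the scatter). This first readable step shows that the position responds to the group it carries, even with hydrogen-bond donor and acceptor counts unchanged. Compound 2 gives only a limit and differs from compound 1 in more than one place, so it adds no step here: the limit of > 10000 nM in this assay, at which 1 of the 3 values shown sits.

From the compounds shown here alone, whether an amine or a carboxylic acid on this carbon would lower the number remains open. One step sets no trend and gives no cause.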